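A ring swap on the side chain of compound 3

This account rests on a few compounds, and the source may have more. Where it says the series, first, only, none or still open, it means among the compounds named here.

In a functional assay on A549 cells (Homo sapiens) for cytotoxicity, read by MTT assay, with a stated time of 48 h (on this read-out higher numbers stand for weaker inhibition and lower numbers for stronger inhibition), three related compounds have entries so far. Compound 1 (`CC(CO)NCCOc1c(O)cc(O)c2c(=O)cc(-c3ccccc3)oc12`) has "not determined" (no result reported) as its entry. Compound 2 (`CN1CCN(CCCOc2c(O)cc(O)c3c(=O)cc(-c4ccccc4)oc23)CC1`) gives > 100000 nM as a limit of the assay and not a number. For the measured compounds named here, compound 3 (`COc1c(OCCCCN2CCCCC2)cc(O)c2c(=O)cc(-c3ccccc3)oc12`) gives 1150 nM as the only true number available, which makes it the sole reference point here.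

The next compound, compound 4 (`COc1c(OCCCN2CCNCC2)cc(O)c2c(=O)cc(-c3ccccc3)oc12`), still awaits testing in this assay and differs from compound 3 in one place. Piperazin-1-yl stands in place of (piperidin-1-yl)methyl on a saturated chain carbon, three bonds along the chain from an oxygen on an aromatic ring (piperazin-1-yl in place of (piperidin-1-yl)methyl on a saturated chain carbon, three bonds along the chain from an oxygen on an aromatic ring). Going by the values given here, no measured pair shows this change, so its size is a judgement anchored only on compound 3 at 1150 nM in this small set. A moderate weakening, somewhat beyond the usual scatter, is expected, and the estimated step is a 4.3-fold higher number from compound 3 to compound 4 (0.64 log units; beyond the scatter) on this basis. The expected value for compound 4 is 5000 nM as a middle estimate, with an estimated range from 1200 nM to 30000 nM for the coming measurement.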

Compound 4, half-maximal inhibitory concentration: 10100 nM
Compound 4: middle estimate off by 2.0-fold (0.31 log units), on the low side; the measured number falls inside the stated range.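

Going from 4-(piperidin-1-yl)butyl to 3-(piperazin-1-yl)propyl gives an 8.8-fold higher number from compound 3 to compound 4 (0.94 log units; beyond the scatter) in this assay and so shows, for the first time in this set, that a change to this side chain can shift the read-out by more than the usual scatter. The swap alters the ring and the chain length together, with a second ring nitrogen entering as the chain shortens. Compound 4 still gives a true number, so this change weakens the effect without reaching the limit of the assay: the limit of > 100000 nM in this assay, at which 1 of the 4 values shown sits.

Whether the ring or the chain length accounts for the step stays open. A 4-(piperazin-1-yl)butyl chain on the same core would separate the two, and a morpholine ring in place of the piperazine would test the second ring nitrogen itself.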